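A Chain Gives Way to 2-Methylphenyl

The source may report more compounds than this note shows. Statements on the series, on what has been measured and on what is new or still open speak of the compounds shown alone.

Compound 1 `CCC(O)Cc1cn(CC(=O)NCc2ccccc2)nn1`: 630 uM
Compound 2 `O=C(O)CCCCc1cn(CC(=O)NCc2ccccc2)nn1`: 1080 uM
Compound 3 `CC(C)(C)OC(=O)NCc1cn(CC(=O)NCc2ccccc2)nn1`: > 2000 uM (a limit)

In an ADME assay on cells (spleen, Mus musculus, strain C57BL/6) for inhibition, read by flow cytometry and propidium iodide staining, with a stated time of 24 h, at 37 degrees C (a lower number here means that less compound is needed, a higher number that more compound is needed for the effect), compound 2 gives 1080 uM and stands level with compound 1: a 1.7-fold higher number from compound 1 to compound 2 (0.23 log units; within the scatter). The value for compound 3 is a limit, > 2000 uM. Compound 4 `Cc1ccccc1-c1cn(CC(=O)NCc2ccccc2)nn1` carries 2-methylphenyl in place of 4-carboxybutyl on an aromatic carbon. Two further measured steps bear on this change: an at least 3.1-fold higher number from compound 1 to compound 3 (0.50 log units; beyond the scatter) and an at least 1.8-fold higher number from compound 2 to compound 3 (0.26 log units; that floor lies within the scatter). All three swap groups on a saturated chain carbon bound to an aromatic carbon, and none brings in an aromatic ring. No step beyond the scatter is therefore expected in this assay, and the expected step is a 1.4-fold lower number from compound 2 to compound 4 (0.13 log units; within the scatter). For compound 4 the estimate is 800 uM, with an expected range of 300 uM to 2000 uM.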

Compound 4, concentration for half-maximal effect: 940 uM
Compound 4: the middle estimate sits 1.2-fold (0.07 log units) below what was measured, and the stated range covers the measured number.
By their numbers in this assay, from the lowest: compounds 1, 4 and 2 (each within the scatter of the next). At a limit, above all of these: compound 3.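

On this aromatic carbon of the five-membered ring with 3 nitrogen, an aromatic ring can stand in for a chain without a step that can be told from the scatter. In this assay, 2-methylphenyl, with 0 hydrogen-bond donors, replaces 4-carboxybutyl with a 1.1-fold lower number from compound 2 to compound 4 (0.06 log units; within the scatter), and it replaces 2-hydroxybutyl with a 1.5-fold higher number from compound 1 to compound 4 (0.17 log units; within the scatter). Nothing measured here gives a reason for this.

Still open, on these data alone, is whether an amine on a chain or a pyridine ring in this place would give a step beyond the scatter.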